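Changing the Six-Membered Ring on Compound 1

The compounds below may be only part of what the source reports. "The series", "measured", "known", "first", "only" and "open" are said of these compounds alone.

Measured compounds:
compound 1, `NC1(CCn2ncc(=O)[nH]c2=O)OC(=O)C(OCc2ccccc2)=C1OCc1ccccc1`: > 100000 nM
compound 2, `Nc1ccn(C[C@H](O)[C@H]2OC(=O)C(OCc3ccccc3)=C2OCc2ccccc2)c(=O)n1`: 7340 nM

Both were tested in a functional assay on MCF7 cells (Homo sapiens) for inhibition, read by MTT assay, with a stated time of 72 h; on this read-out lower numbers stand for stronger inhibition and higher numbers for weaker inhibition. For compound 1 the result is not a number but a limit of the assay, > 100000 nM, meaning no inhibition was seen up to the highest concentration tested. Compound 1 therefore stands at the limit of > 100000 nM in this assay, at which 1 of the 2 values shown sits. Compound 2 gives 7340 nM, a measurable though weak value.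

Compound 3, `NC1(CCn2c(=O)[nH]c(=O)[nH]c2=O)OC(=O)C(OCc2ccccc2)=C1OCc1ccccc1`, has not yet been measured. It differs from compound 1 in one place: a group of 9 heavy atoms (3 carbon, 3 nitrogen, 3 oxygen; one six-membered aromatic ring with 3 hetero atoms) in place of a group of 8 heavy atoms (3 carbon, 3 nitrogen, 2 oxygen; one six-membered aromatic ring with 3 hetero atoms), on a saturated chain carbon, two bonds along the chain from a saturated ring carbon. Going by the values given here, no pair of measured compounds shows what this particular swap does, so any expectation rests on compound 1 alone. Because compound 1 already sits at the limit of > 100000 nM in this assay, at which 1 of the 2 values shown sits, there is little room for the new group to make matters worse, and nothing in the data suggests a gain. The expected step of a number no higher from compound 1 to compound 3 (the limit leaves the size open) is none beyond the usual scatter. Compound 3 is thus estimated at 100000 nM, with a range from 30000 nM to 300000 nM, and most probably it will again be reported only as a limit.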

Compound 3, half-maximal inhibitory concentration: 84900 nM
Compound 3: the middle estimate sits 1.2-fold (0.07 log units) above what was measured; low and high end bracket the measured number.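

Swapping the group on the saturated chain carbon, two bonds along the chain from a saturated ring carbon, gives in this assay an at least 1.1-fold lower number from compound 1 to compound 3 (0.07 log units; that floor lies within the scatter) and so offers the first reading of this change. Unlike compound 1, compound 3 gives a real number, 84900 nM and not a limit of the assay, so this position now has a measured starting point against which further changes could be set. The true size of the step cannot be read, and it may be no more than the floor printed with it, because compound 1 has only a limit and not a number: the limit of > 100000 nM in this assay, at which 1 of the 3 values shown sits.

The compounds shown leave open whether a different group at this position, such as an amine or a carboxylic acid in place of the six-membered aromatic ring, or a longer chain, would move the number further. Compound 2 differs from compound 1 in more than one place, and its value says nothing about this particular swap.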